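From methoxycarbonyl to hydroxymethyl on a shared core

The compounds below may be only part of what the source reports. "The series", "measured", "known", "first", "only" and "open" are said of these compounds alone.

Measured in a functional assay on ZR-75-1 cells (Homo sapiens) for cytotoxicity, read by sulforhodamine B assay, with a stated time of 3 days; on this read-out lower numbers stand for an effect already at smaller amounts and higher numbers for an effect only at larger amounts of compound:
- compound 1 `Cc1coc(-c2ccc3c(c2O)CCCC3)c1C(=O)O` gives 21.7 uM
- compound 2 `COC(=O)c1c(C)coc1-c1ccc2c(c1OC)CCCC2(C)C` gives 34.5 uM
- compound 3 `COc1c(-c2occ(C)c2COC(C)=O)ccc2c1CCCC2(C)C` gives 15.5 uM

Compound 2 sits at the upper end of these three numbers. Its value lies within the scatter of that of compound 1, and only compound 3 stands beyond the scatter from it. The next compound, compound 4 `COc1c(-c2occ(C)c2CO)ccc2c1CCCC2(C)C`, has not yet been measured in this assay. It carries hydroxymethyl in place of methoxycarbonyl on an aromatic carbon. Among the measured compounds shown here, one measured step bears on this change, as it replaces the same methoxycarbonyl with acetoxymethyl: a 2.2-fold lower number from compound 2 to compound 3 (0.35 log units; beyond the scatter). For the measured compounds named here, that step is modest, and no measured step reaches hydroxymethyl itself, so the guidance is limited. A modest move towards a lower number is expected, of a size similar to that step, with compound 3 at 15.5 uM as the closest guide. The expected change is a 1.8-fold lower number from compound 2 to compound 4 (0.26 log units; within the scatter). For compound 4 the estimated value is 19 uM, with an expected range of 8 uM to 40 uM.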

Compound 4, concentration for half-maximal effect: 15 uM
Beside the measured number, compound 4's estimate is 1.3-fold (0.10 log units) above it; measured number inside the range.
By their numbers in this assay, from the lowest: compounds 4, 3, 1 and 2 (each within the scatter of the next, the first and the last beyond it).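

In this assay, hydroxymethyl on this aromatic carbon of the five-membered ring gives a 2.3-fold lower number from compound 2 to compound 4 (0.36 log units; beyond the scatter), a modest step that shows the lower number does not depend on keeping an acetyl on the oxygen. Removing that acetyl leaves no readable difference, with a 1.0-fold lower number from compound 3 to compound 4 (0.01 log units; within the scatter), so the free hydroxymethyl and its acetylated form cannot be told apart on this shared core. Nothing available here explains why either group differs from methoxycarbonyl.

Going by these compounds, it remains open whether an aminomethyl group or a methoxymethyl group at this place would match hydroxymethyl. On these data alone, it is also open whether a longer chain ending in hydroxyl would hold the number or move it in either direction.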